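The source may hold more compounds than are shown below. What is called first, only, known or untested is meant among the compounds shown, and "the series" means these compounds.

Compound 1 `CS/C(=N\C(=O)c1csc([N+](=O)[O-])c1)NC(=O)c1csc([N+](=O)[O-])c1` and compound 2 `CS/C(=N\C(=O)c1cc2ccccc2s1)NC(=O)c1cc2ccccc2s1` share the same arrangement around a carbon with a double bond to nitrogen, but the difference between the two cores is not broken down here. In a functional assay on PC-3 cells (Homo sapiens) for cytotoxicity, read by MTT assay, with a stated time of 72 h (a lower number here means a stronger inhibitor of growth, a higher number a weaker inhibitor of growth), compound 1 gives 82500 nM, while compound 2 gives 39400 nM. Compound 3 `O=C(/N=C(/NC(=O)c1csc([N+](=O)[O-])c1)[Se]Cc1ccccc1)c1csc([N+](=O)[O-])c1` is compound 1 with a group of 8 heavy atoms (7 carbon, 1 selenium; one six-membered aromatic ring of carbon only) in place of a group of 2 heavy atoms (1 carbon, 1 sulfur; no ring), on a carbon with a double bond to nitrogen, and in this assay compound 3 gives 69200 nM, so that the step from compound 1 to compound 3 is a 1.2-fold lower number from compound 1 to compound 3 (0.08 log units; within the scatter). Compound 4 `O=C(/N=C(/NC(=O)c1cc2ccccc2s1)[Se]Cc1ccccc1)c1cc2ccccc2s1` has not yet been measured; it carries a group of 8 heavy atoms (7 carbon, 1 selenium; one six-membered aromatic ring of carbon only) in place of a group of 2 heavy atoms (1 carbon, 1 sulfur; no ring), on a carbon with a double bond to nitrogen, and the place of this change is the same kind of change as in compound 3, since both place lines read word for word alike. The account therefore expects a similar step for compound 4, namely a 1.2-fold lower number from compound 2 to compound 4 (0.08 log units; within the scatter), resting on the step seen from compound 1 to compound 3 of a 1.2-fold lower number from compound 1 to compound 3 (0.08 log units; within the scatter), which lay within the scatter. On that footing compound 4 is estimated to give 33000 nM in this assay, with a range expected from 15000 nM to 75000 nM.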

Compound 4, concentration for total growth inhibition: 58400 nM
Compound 4: the middle estimate sits 1.8-fold (0.25 log units) below what was measured; low and high end bracket the measured number.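

In this assay, putting the selenium-bearing group of 8 heavy atoms on the carbon with a double bond to nitrogen, in place of methylsulfanyl, gives a 1.5-fold higher number from compound 2 to compound 4 (0.17 log units; within the scatter), so on this core too the step stays within the usual scatter. Set beside the earlier step, the two cores cannot be told apart: the same change on two cores in this assay, a 1.2-fold lower number (0.08 log units; within the scatter) from compound 1 to compound 3 and a 1.5-fold higher number (0.17 log units; within the scatter) from compound 2 to compound 4, 1.8-fold (0.25 log units) apart, within the scatter of two such steps. For these two pairs, then, the change carries from one core to the other without a difference that can be read, but this does not establish its direction or size, and two pairs say nothing about any further core.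

The compounds shown leave open how an amine or a longer chain on that same carbon would read in this assay. They also leave open the separate parts played by the selenium and by the six-membered aromatic ring, since the entering group brings both together.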